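From methylsulfonyl to cyano on a shared core

The source may hold more compounds than are shown below. What is called first, only, known or untested is meant among the compounds shown, and "the series" means these compounds.

Compound 1 `COC(=O)C1=C(C)NC(c2nccs2)=N[C@]1(C)c1ccc(F)cc1` (178 ug/mL)
Compound 2 `COC(=O)C1=C(C)NC(c2nccs2)=NC1(C)c1ccc(F)cc1Cl` (18 ug/mL)
Compound 3 `COC(=O)C1=C(C)NC(c2nccs2)=NC1(C)c1ccc(S(C)(=O)=O)cc1` (365 ug/mL)

In a physicochemical assay for solubility, read by HPLC, in phosphate buffer, at pH 6.5 (on this read-out higher numbers stand for higher solubility and lower numbers for lower solubility), compound 3 gives 365 ug/mL, the highest of the three numbers. Compound 1 is the nearest at 178 ug/mL and compound 2 the furthest at 18 ug/mL, and both gaps lie beyond the scatter.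

The next compound to be measured is compound 4 `COC(=O)C1=C(C)NC(c2nccs2)=NC1(C)c1ccc(C#N)cc1`, which has not yet been tested. It carries cyano in place of methylsulfonyl on an aromatic carbon, para to a large group (cyano in place of methylsulfonyl on an aromatic carbon).

For the measured compounds named here, no two measured compounds differ in one place only, so no direct step is available as a guide. With so few values, any expectation is tentative. The closest reference is compound 1 at 178 ug/mL, and compound 4 is expected to land nearer that number than the top value, without reaching as low as compound 2. A fall of a 3.0-fold lower number from compound 3 to compound 4 (0.48 log units; beyond the scatter) is therefore expected in this assay, most likely beyond the scatter. The estimate for compound 4 is 120 ug/mL (expected range 40 ug/mL to 350 ug/mL)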

Compound 4, solubility: 87 ug/mL
Compound 4: middle estimate off by 1.4-fold (0.14 log units), on the high side, and the stated range covers the measured number.
By their numbers in this assay, from the lowest: compound 2; then compound 4; then compound 1; then compound 3.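

In this assay, for the compounds shown here, the change of methylsulfonyl to cyano on an aromatic carbon, para to a large group, gives the first direct reading at this position: a 4.2-fold lower number from compound 3 to compound 4 (0.62 log units; beyond the scatter) is a modest step, but it lies beyond the scatter, so the read-out does depend on which of these two groups the ring carries. Taken as a whole-group change on the saturated ring carbon of the shared core, 4-cyanophenyl in place of 2-chloro-4-fluorophenyl gives a 4.8-fold higher number from compound 2 to compound 4 (0.68 log units; beyond the scatter) in the same assay, so the cyano compound falls well short of the methylsulfonyl compound yet remains clearly above the chloro-fluoro compound. No measurement shown here bears on what lies behind either step.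

Going by these compounds, two groups at one position cannot define a trend, so what an amine, a carboxylic acid or a longer chain such as methoxyethoxy would do on that same aromatic carbon remains open. On these data alone, it also remains open whether the step between methylsulfonyl and cyano would keep its direction and size on a shared core carrying a different ester or a different ring substituent.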